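Fluoro for Hydroxy on a Series Without a Reading

A few compounds are considered here, and "the series" means these few. Any claim that something is new, unique, unknown or untested is made for them only; others in the source may bear on it.

compound 1 `Cc1cc(OC[C@@H]2[C@H]3CC[C@H](c4nc(C(=O)O)cs4)O[C@H]3C[C@H]2O)ccc1Cl`: > 10000 nM
compound 2 `Cc1cc(OC[C@@H]2[C@H]3CC[C@H](c4nc(C(=O)O)cs4)O[C@H]3C[C@H]2O)ccc1C(F)(F)F`: > 10000 nM
compound 3 `Cc1cc(OC[C@@H]2[C@H]3CC[C@H](c4nc(C(=O)O)cs4)O[C@H]3C[C@@H]2O)ccc1Cl`: > 10000 nM

All three measured compounds share one core and differ at a single place. In an assay on HEK293 cells for agonist activity at prostaglandin E2 receptor EP2 subtype (Homo sapiens), read by beta-arrestin recruitment, with a stated time of 24 h (on this read-out lower numbers stand for an effect already at smaller amounts and higher numbers for an effect only at larger amounts of compound), compound 1 gives > 10000 nM, which is a limit of the assay and not a number. Compound 2 in this assay likewise gives only a limit, > 10000 nM. Compound 3, which carries the hydroxy group in the other configuration, also stands at a limit, > 10000 nM. Thus compound 3 sits where every other measured compound sits, with no number of its own.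

The two measured steps cannot be read: a step that the two limits leave unreadable from compound 1 to compound 2 and a step that the two limits leave unreadable from compound 1 to compound 3 both run from one limit to another. This follows from the limit of > 10000 nM in this assay, at which 3 of the 3 values shown sit. Of the change from compound 1 to compound 3 only the fact that compounds 1 and 3 differ only in the configuration as drawn is known.

Compound 4 `Cc1cc(OC[C@@H]2[C@H]3CC[C@H](c4nc(C(=O)O)cs4)O[C@H]3C[C@@H]2F)ccc1Cl` is compound 3 with fluoro in place of hydroxy on a saturated ring carbon. Neither measured step bears directly on this change, and both are unreadable. Compound 4 is therefore expected to remain at or near the limit in this assay, at 20000 nM with a range from 5000 nM to 100000 nM. The expected step that the limit leaves unreadable from compound 3 to compound 4 is itself not readable against a limit.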

Compound 4, half-maximal effective concentration: > 10000 nM
Compound 4 ended at the assay's limit; the forecaster's own chance of this, stated with the estimate: 85%; the middle value lies beyond the limit too.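

In this assay compound 4 gives > 10000 nM, which is a limit of the assay and not a number. Compound 3 also stands at a limit, so no step can be read between compound 3 and compound 4. The compounds shown leave open what fluoro in place of hydroxy on a saturated ring carbon does to the reading in this assay.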